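The compounds below may be only part of what the source reports. "The series", "measured", "known", "first", "only" and "open" are said of these compounds alone.

Compound 2 `Cc1ccc(NC2=CC(=O)c3c(nc4n3[C@H]3OC[C@@H](O)[C@H]3OC4)C2=O)cc1C` was examined in a functional assay on ECa-109 cells for inhibition, with ECa-109 cell line (Homo sapiens) as the target, read by sulforhodamine B assay (a higher number here means a weaker inhibitor, a lower number a stronger inhibitor), alongside compound 1 `Cc1ccc(NC2=CC(=O)c3nc4n(c3C2=O)[C@H]2OC[C@@H](O)[C@H]2OC4)cc1` and compound 3 `O=C1C=C(Nc2ccc(C(F)(F)F)cc2)C(=O)c2c1nc1n2[C@H]2OC[C@@H](O)[C@H]2OC1`. In this assay, among the compounds with values here, compound 2 gives 4090 nM, compound 1 gives 3480 nM and compound 3 gives 5500 nM; the three numbers sit close together, and the only single-point step among them, a 1.6-fold higher number from compound 1 to compound 3 (0.20 log units; within the scatter), does not leave the scatter. The next compound, compound 4 `Cc1ccc(NC2=CC(=O)c3c(nc4n3[C@H]3OC[C@@H](O)[C@H]3OC4)C2=O)cc1`, differs from compound 2 by hydrogen in place of methyl on an aromatic carbon, so that the 3,4-dimethylphenyl of compound 2 becomes the 4-methylphenyl of compound 4. Within the data shown here, no measured pair shows this particular change; the one step that concerns the same aromatic ring exchanges one group for another and stays within the scatter, so there is no sign in the data that a change on this ring moves the number in this assay. Compound 4 is therefore expected to give about 3800 nM in this assay, with a range from 1900 nM to 7600 nM, meaning an expected step of a 1.1-fold lower number from compound 2 to compound 4 (0.03 log units; within the scatter) that lies within the usual scatter.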

Compound 4, half-maximal inhibitory concentration: > 4000 nM
Compound 4: only a limit was reported (the forecaster's own chance of this, stated with the estimate: 5%); at least 1.0-fold (0.02 log units) between middle value and limit.
By their numbers in this assay, from the lowest: compounds 1, 2 and 3 (each within the scatter of the next).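

For compound 4 only a limit is reported, so the step from compound 2 to compound 4 cannot be read: the limit of > 4000 nM in this assay, at which 1 of the 4 values shown sits.

The compounds shown leave open whether hydrogen in place of methyl on this aromatic ring moves the number in this assay at all.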